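The source may hold more compounds than are shown below. What is called first, only, known or untested is meant among the compounds shown, and "the series" means these compounds.

Measured so far in a functional assay on KYSE-410 cells (Homo sapiens) for antiproliferative activity, read by MTT assay, with a stated time of 72 h; a lower number here means a stronger inhibitor, a higher number a weaker inhibitor:
- compound 1 `O=C(Nc1cccc(F)c1)c1cc(=O)[nH]c2cc(F)ccc12`: > 20000 nM
- compound 2 `O=C(Nc1cc(F)cc(F)c1)c1cc(=O)[nH]c2cc(F)ccc12`: > 20000 nM

In this assay compound 1 gives no number, only a limit of > 20000 nM. Compound 2 likewise gives only a limit of > 20000 nM. The standing of the pair is therefore summed up as the limit of > 20000 nM in this assay, at which 2 of the 2 values shown sit.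

Compound 3 `CC(C)(C)c1ccc(-c2ccc3c(C(=O)Nc4cccc(F)c4)cc(=O)[nH]c3c2)cc1` departs from compound 1 in a single place: 4-(tert-butyl)phenyl in place of fluoro on an aromatic carbon. Among the compounds with values here, the only measured step, a step that the two limits leave unreadable from compound 1 to compound 2, lies elsewhere in the molecule and has no readable size, so no measured step gives a direct guide to this change. The new group is far larger than the fluoro it replaces, and a clear change in this assay is plausible. With compound 1 held at the limit of > 20000 nM, any change that can be read would be toward stronger inhibition, although a further limit remains quite possible. The expected step, a rough estimate, is an at least 2.5-fold lower number from compound 1 to compound 3 (0.39 log units; beyond the scatter). In this assay the estimate for compound 3 is 8000 nM, expected to fall between 1500 nM and 30000 nM.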

Compound 3, half-maximal inhibitory concentration: > 20000 nM
Compound 3 gave a limit, no number; the forecaster's own chance of this, stated with the estimate: 35%; middle value at least 2.5-fold (0.39 log units) from the limit.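

Compound 3, like compound 1, gives only a limit in this assay, so no step between them can be read, and the three compounds stand together: the limit of > 20000 nM in this assay, at which 3 of the 3 values shown sit.

The compounds shown leave open whether 4-(tert-butyl)phenyl in place of fluoro changes the inhibition at all, and how large any such change would be.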